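The source may report more compounds than this note shows. Statements on the series, on what has been measured and on what is new or still open speak of the compounds shown alone.

Measured in a functional assay on MCF7 cells (Homo sapiens) for cytotoxicity, read by MTT assay, with a stated time of 48 h; a lower number here means a stronger inhibitor, a higher number a weaker inhibitor:
Compound 1, `Cc1ccc(S(=O)(=O)/N=C(/CCNC2=CC(=O)c3ccccc3C2=O)Nc2ccc(Cl)cc2)cc1`: 7080 nM
Compound 2, `Cc1ccc(S(=O)(=O)/N=C(/CCNC2=CC(=O)c3ccccc3C2=O)Nc2ccc(F)cc2)cc1`: 4260 nM
Compound 3, `Cc1ccc(S(=O)(=O)/N=C(/CCNC2=CC(=O)c3ccccc3C2=O)Nc2ccccc2I)cc1`: 15500 nM

Among these three, compound 3 stands with the highest number. The nearest to it is compound 1, as the step of a 2.2-fold higher number from compound 1 to compound 3 (0.34 log units; beyond the scatter) shows; the furthest is compound 2, as seen in a 3.6-fold higher number from compound 2 to compound 3 (0.56 log units; beyond the scatter). Compound 1 and compound 2 themselves differ only by a 1.7-fold lower number from compound 1 to compound 2 (0.22 log units; within the scatter), which lies within the scatter.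

Compound 4, `Cc1ccc(S(=O)(=O)/N=C(/CCNC2=CC(=O)c3ccccc3C2=O)Nc2cccc(C(F)(F)F)c2)cc1`, has not yet been measured in this assay. It differs from compound 3 as follows: 3-(trifluoromethyl)phenyl in place of 2-iodophenyl on an amine nitrogen.

The two steps that bear on this change are the ones leading to compound 3, a 2.2-fold higher number from compound 1 to compound 3 (0.34 log units; beyond the scatter) and a 3.6-fold higher number from compound 2 to compound 3 (0.56 log units; beyond the scatter). Both replaced 4-chlorophenyl or 4-fluorophenyl with 2-iodophenyl, and both raised the number modestly. Leaving 2-iodophenyl for another substituted phenyl is therefore expected to move the number back toward the level of compound 1 and compound 2, though no measured compound carries 3-(trifluoromethyl)phenyl, so the size of that return is uncertain. The expected step is a 2.4-fold lower number from compound 3 to compound 4 (0.38 log units; beyond the scatter), a modest lowering. Compound 4 is thus estimated at 6500 nM, with a range from 3000 nM to 15000 nM.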

Compound 4, half-maximal inhibitory concentration: 89100 nM
Estimate against measurement, compound 4: 14-fold (1.14 log units) below; the measured number lies above the stated range.
By their numbers in this assay, from the lowest: compounds 2 and 1 (each within the scatter of the next); then compound 3; then compound 4.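

In this assay, the change from 2-iodophenyl to 3-(trifluoromethyl)phenyl on the amine nitrogen continues the rise seen on leaving 4-chlorophenyl and 4-fluorophenyl, with a 5.7-fold higher number from compound 3 to compound 4 (0.76 log units; beyond the scatter), so leaving 2-iodophenyl does not by itself bring the number back. Set against the two earlier compounds, the same group gives large steps, a 21-fold higher number from compound 2 to compound 4 (1.32 log units; beyond the scatter) and a 13-fold higher number from compound 1 to compound 4 (1.10 log units; beyond the scatter), which shows that the aryl group on this nitrogen can move the number much further than the first three compounds revealed, while compound 1 and compound 2, within the scatter of each other, keep the lowest numbers of the four. Nothing given here accounts for the size of this rise.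

The compounds shown leave open whether the rise follows the trifluoromethyl group itself or where it sits on the ring, a question that 4-(trifluoromethyl)phenyl and 3-chlorophenyl on the same nitrogen would help to separate. They also leave open how an unsubstituted phenyl on this nitrogen would compare with all four.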